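Hydroxyl to Chlorine on a Hydrazone Side Group

The compounds below may be only part of what the source reports. "The series", "measured", "known", "first", "only" and "open" are said of these compounds alone.

Compound 1 (`CCCSc1nc(N/N=C/c2ccc(C)cc2)c2nnn(Cc3ccccc3)c2n1`): > 64000 nM (a limit)
Compound 2 (`CCCSc1nc(N/N=C(\C)c2ccc(O)cc2)c2nnn(Cc3ccccc3)c2n1`): 16700 nM

Going by the values given here, in a functional assay on MGC-803 cells (Homo sapiens) for antiproliferative activity, read by MTT assay, with a stated time of 72 h (a higher number here means a weaker inhibitor, a lower number a stronger inhibitor), compound 2 gives the only actual number, 16700 nM. Compound 1 reached only a limit, > 64000 nM.

Compound 3 (`CCCSc1nc(N/N=C/c2ccc(Cl)cc2)c2nnn(Cc3ccccc3)c2n1`) differs from compound 2 in one place: a group of 9 heavy atoms (7 carbon, 1 nitrogen, 1 chlorine; one six-membered aromatic ring of carbon only) in place of a group of 10 heavy atoms (8 carbon, 1 nitrogen, 1 oxygen; one six-membered aromatic ring of carbon only), on a nitrogen on an aromatic ring. Like compound 1, compound 3 carries no oxygen in this group. Among the compounds with values here, the single measured step, an at least 3.8-fold lower number from compound 1 to compound 2 (0.58 log units; beyond the scatter), therefore points towards a weaker result, though chlorine itself is untested. The expected change is a 1.8-fold higher number from compound 2 to compound 3 (0.25 log units; within the scatter). Compound 3 is estimated at 30000 nM, with an expected range of 10000 nM to 64000 nM.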

Compound 3, half-maximal inhibitory concentration: > 64000 nM
Compound 3: a limit, no number; the forecaster's own chance of this, stated with the estimate: 35%; at least 2.1-fold (0.32 log units) between middle value and limit.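

Placing the chlorine-bearing group on this nitrogen gives an at least 3.8-fold higher number from compound 2 to compound 3 (0.58 log units; beyond the scatter). Among these three compounds, only compound 2, whose group holds oxygen and a hydrogen-bond donor, gives an actual number, while compound 3 joins compound 1 at a limit: the limit of > 64000 nM in this assay, at which 2 of the 3 values shown sit. The step between compound 1 and compound 3 cannot be read, as both values are limits.

The entering group also has one carbon fewer, so this step cannot separate that difference from the change from oxygen to chlorine. As far as these compounds go, how an amine or a methoxy group would read here remains open.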